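Cyano in place of hydroxy on the shared core

A few compounds are considered here, and "the series" means these few. Any claim that something is new, unique, unknown or untested is made for them only; others in the source may bear on it.

In a functional assay on HT-29 cells (Homo sapiens) for inhibition, with a stated time of 72 h (a lower number here means a stronger inhibitor, a higher number a weaker inhibitor), compound 1 (`COc1ccc(S(=O)(=O)N2CCc3cccc(-c4ccncc4)c32)cc1`) gives 87.5 nM and compound 2 (`COc1ccc(S(=O)(=O)N2CCc3cccc(-c4ccc(O)cc4)c32)cc1`) gives 133 nM so the two stand within the scatter of each other. Compound 3 (`COc1ccc(S(=O)(=O)N2CCc3cccc(-c4ccc(C#N)cc4)c32)cc1`) differs from compound 2 by cyano in place of hydroxy on an aromatic carbon with cyano in place of hydroxy on an aromatic carbon, para to a large group. Within the data shown here, the only measured step that bears on this is a 1.5-fold higher number from compound 1 to compound 2 (0.18 log units; within the scatter) and it stays within the scatter. No step beyond the scatter is therefore expected in this assay and the estimate reads a 1.1-fold lower number from compound 2 to compound 3 (0.04 log units; within the scatter) for this change. Compound 3 is expected at 120 nM (estimated range 45 nM to 320 nM).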

Compound 3, half-maximal inhibitory concentration: 24.2 nM
For compound 3 the middle estimate is 5.0-fold (0.70 log units) above the measured one; measured number outside the range, below it.
By their numbers in this assay, from the lowest: compound 3; then compounds 1 and 2 (each within the scatter of the next).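

In this assay the group on this aromatic carbon, para to a large group, turns out to matter: cyano in place of hydroxy brings a 5.5-fold lower number from compound 2 to compound 3 (0.74 log units; beyond the scatter) and so goes beyond the scatter, which the earlier step did not. Exchanging pyridin-4-yl for 4-cyanophenyl likewise gives a 3.6-fold lower number from compound 1 to compound 3 (0.56 log units; beyond the scatter) and so separates the two aryl groups. No evidence shown here accounts for these steps. As far as these compounds go, whether an amine or a carboxylic acid at this place would stand nearer compound 3 or compound 2 remains open.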